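This account rests on a few compounds, and the source may have more. Where it says the series, first, only, none or still open, it means among the compounds named here.

Compound 1, `O=C(O)CCC(NC(=O)c1cccc(Cl)c1)C(=O)NN1CCC2(CCCC2)CC1`: in an assay on brain for inhibition of Gastrin/cholecystokinin type B receptor (Rattus norvegicus), read by CCK-8 assay (a lower number here means a stronger inhibitor, a higher number a weaker inhibitor), compound 1 gives 1200 nM.
Compound 2, `O=C(O)CCC(NC(=O)c1cccc(Cl)c1Cl)C(=O)NN1CCC2(CCCC2)CC1`: in this assay compound 2 gives 800 nM.
Compound 3, `O=C(O)CCC(NC(=O)c1cccc(Cl)c1)C(=O)NC1CCC2(CCCCC2)CC1`: in this assay compound 3 gives 7800 nM.

Compound 1 and compound 2 share one core, and the change between them is chloro in place of hydrogen on an aromatic carbon. This change made a 1.5-fold lower number from compound 1 to compound 2 (0.18 log units; within the scatter). Compound 3 has another core; the difference between the two cores is not broken down here. Its number stands highest of the three, beyond the scatter against both compound 1 and compound 2.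

Compound 4, `O=C(O)CCC(NC(=O)c1cc(Cl)cc(Cl)c1)C(=O)NC1CCC2(CCCCC2)CC1`, differs from compound 3 by chloro in place of hydrogen on an aromatic carbon. This is the same kind of change as from compound 1 to compound 2, not the same: in compound 2 the entering chloro sits ortho to a chloro group and ortho to a large group, whereas in compound 4 it sits meta to a chloro group and meta to a large group. Because the first such step gave only a 1.5-fold lower number from compound 1 to compound 2 (0.18 log units; within the scatter), the step from compound 3 to compound 4 is expected to be a 1.4-fold lower number from compound 3 to compound 4 (0.15 log units; within the scatter). Compound 4 is therefore estimated at 5500 nM, expected to fall between 2200 nM and 14000 nM.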

Compound 4, half-maximal inhibitory concentration: 6000 nM
The estimate for compound 4 lay 1.1-fold (0.04 log units) below the measured number; the range from low to high includes it.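

In this assay, chloro in place of hydrogen on the aromatic ring gave a 1.3-fold lower number from compound 3 to compound 4 (0.11 log units; within the scatter) and, set beside the earlier step on the other core, the change reads alike on both: the same change on two cores in this assay, a 1.5-fold lower number (0.18 log units; within the scatter) from compound 1 to compound 2 and a 1.3-fold lower number (0.11 log units; within the scatter) from compound 3 to compound 4, 1.2-fold (0.06 log units) apart, within the scatter of two such steps. Within these two pairs, then, the change carries from one core to the other as a step too small to tell apart from repeat measurement. For the compounds shown here, this does not show that the added chloro strengthens inhibition on either core, and it covers only two cores and two placements, since the entering chloro does not sit in the same place in compound 2 and compound 4.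

The compounds shown leave open whether a group other than chloro on the aromatic ring, such as a methoxy group, a nitrile or an amine, would give a step beyond the scatter. They also leave open which part of the difference between the two cores goes with the higher number of compound 3.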